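This account rests on a few compounds, and the source may have more. Where it says the series, first, only, none or still open, it means among the compounds named here.

Compound 2 `CCCOC1CCCN(CCCCOc2ccccc2/C=C/c2ccccc2)C1` and compound 1 `CCN1CCN(CCCCOc2ccccc2/C=C/c2ccccc2)CC1` share the same core. In a functional assay on the whole organism with Mus musculus as the target, in the maximal electroshock model, at a dose of 50 mg/kg by the oral route (on this read-out lower numbers stand for less inhibition and higher numbers for more inhibition at the one dose given (going by the name of the read-out)), compound 2 gives 0%, the lowest of the two numbers, while compound 1 gives 33.3%, a gap beyond the usual scatter. Compound 3 `CC1CCCN(CCCCOc2ccccc2/C=C/c2ccccc2)C1` has not been measured. It differs from compound 2 by methyl in place of propoxy on a saturated ring carbon. Going by the values given here, no measured pair shows what this change does, so the step can only be guessed, and a modest rise at most is expected. Compound 3 is expected to give about 15% in this assay, somewhere between 0% and 45%. The expected step is a number 15 percentage points higher from compound 2 to compound 3 (beyond the scatter), near the edge of the scatter.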

Compound 3, a percentage reported as inhibition, in the whole organism at one dose (the size of the read-out at that dose, not a potency): 12.5%
Estimate against measurement, compound 3: 2.5 percentage points above; the measured number falls inside the stated range.
By their numbers in this assay, from the lowest: compound 2; then compound 3; then compound 1.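

Methyl in place of propoxy on a saturated ring carbon gives a number 12.5 percentage points higher from compound 2 to compound 3 (beyond the scatter) in this assay and is the first step read at this position, so the group there does alter the outcome. 3-methylpiperidin-1-yl in place of 4-ethylpiperazin-1-yl gives a number 20.8 percentage points lower from compound 1 to compound 3 (beyond the scatter) and shows that the methyl compound still falls short of compound 1. Nothing measured here explains either step. Going by these compounds, whether an ethyl or a hydroxyl group on that ring carbon would come closer to compound 1 stays open.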